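Methyl Step on a Limit-Bound Fluoro Analogue

A few compounds are considered here, and "the series" means these few. Any claim that something is new, unique, unknown or untested is made for them only; others in the source may bear on it.

Compound 1 `O=C(NC/C=C\Cn1ccc(=O)[nH]c1=O)c1ccccc1` is the parent of this small set. In an ADME assay on WI-38 cells (Homo sapiens) for cytotoxicity, read by MTT assay, with a stated time of 72 h (on this read-out lower numbers stand for stronger inhibition and higher numbers for weaker inhibition), compound 1 gives 6600 nM. Compound 2 `Cc1cn(C/C=C\CNC(=O)c2ccccc2)c(=O)[nH]c1=O` carries the change (methyl in place of hydrogen on an aromatic carbon). In this assay compound 2 gives 4300 nM, and the step of a 1.5-fold lower number from compound 1 to compound 2 (0.19 log units; within the scatter) stays within the scatter, so the two values are read as equivalent.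

Compound 3 `O=C(NC/C=C\Cn1ccc(=O)[nH]c1=O)c1ccc(F)cc1` differs from compound 1 by fluoro in place of hydrogen on an aromatic carbon. In this assay compound 3 returns only a limit, > 100000 nM, and not a number. That value sits at the limit of > 100000 nM in this assay, at which 1 of the 3 values shown sits. The step of an at least 15-fold higher number from compound 1 to compound 3 (1.18 log units; beyond the scatter) is beyond the scatter, the one large movement in the set.

Compound 4 `Cc1cn(C/C=C\CNC(=O)c2ccc(F)cc2)c(=O)[nH]c1=O` has not been measured. It differs from compound 3 by methyl in place of hydrogen on an aromatic carbon. The place of this change is word for word the place of the change from compound 1 to compound 2, so it is the same change, made twice among these compounds. The measured instance moved the read-out only by a 1.5-fold lower number from compound 1 to compound 2 (0.19 log units; within the scatter). The second instance starts from compound 3, which sits at the limit of > 100000 nM in this assay, at which 1 of the 3 values shown sits. No number inside the measurable range is expected for compound 4. For compound 4 the expected step is a step that the limit leaves unreadable from compound 3 to compound 4, resting on the within-scatter step a 1.5-fold lower number from compound 1 to compound 2 (0.19 log units; within the scatter). Compound 4 is therefore estimated at 150000 nM, with a range from 50000 nM to 500000 nM, and most probably the assay will again report only a limit.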

Compound 4, half-maximal inhibitory concentration: 100 nM
Compound 4: the middle estimate sits 1500-fold (3.18 log units) above what was measured, and the stated range ends above it.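

In this assay, methyl in place of hydrogen on an aromatic carbon gives an at least 1000-fold lower number from compound 3 to compound 4 (3.00 log units; beyond the scatter), and fluoro in place of hydrogen on an aromatic carbon gives a 43-fold lower number from compound 2 to compound 4 (1.63 log units; beyond the scatter). The methyl change therefore cannot be carried from one core to the other as a fixed increment, since its effect depends on whether the fluoro group is present: the same change on two cores in this assay, a 1.5-fold lower number (0.19 log units; within the scatter) from compound 1 to compound 2 and an at least 1000-fold lower number (3.00 log units; beyond the scatter) from compound 3 to compound 4, at least 650-fold (2.81 log units) apart, beyond the scatter of two such steps. The fluoro change does not carry over either, its direction being opposite on the two cores, but these four compounds give no reason for the difference and no rule for other cores, and the value of compound 3 is a limit and not a number, so the gap between the steps is only a bound: the same change on two cores in this assay, an at least 15-fold higher number (1.18 log units; beyond the scatter) from compound 1 to compound 3 and a 43-fold lower number (1.63 log units; beyond the scatter) from compound 2 to compound 4, at least 650-fold (2.81 log units) apart, beyond the scatter of two such steps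

Left open is whether the low value of compound 4 needs fluoro itself, or whether chloro or methoxy in the same place would pair with methyl in the same way. Also open, from the compounds shown here alone, is whether ethyl or a longer chain in place of the methyl would keep that value, or whether the combination holds only for methyl and fluoro.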